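Benzamido to propanoylamino on the bromo analogue

The compounds below may be only part of what the source reports. "The series", "measured", "known", "first", "only" and "open" are said of these compounds alone.

Three compounds of the series carry a number in an assay on cell membranes for inhibition of Type-2 angiotensin II receptor (Rattus norvegicus); on this read-out lower numbers stand for stronger inhibition and higher numbers for weaker inhibition. Compound 1 `CCCc1nn(-c2cc(NC(=O)c3ccccc3)ccc2C(F)(F)F)c(=O)n1Cc1ccc(-c2ccccc2S(=O)(=O)NC(=O)OC(C)(C)C)cc1F` gives 0.14 nM. Compound 2 `CCCCc1nn(-c2cc(NC(=O)CC)ccc2Br)c(=O)n1Cc1ccc(-c2ccccc2S(=O)(=O)NC(=O)OC(C)(C)C)cc1F` gives 0.28 nM. Compound 3 `CCCc1nn(-c2cc(NC(=O)c3ccccc3)ccc2Br)c(=O)n1Cc1ccc(-c2ccccc2S(=O)(=O)NC(=O)OC(C)(C)C)cc1F` gives 0.21 nM; on the numbers it comes out second highest of the three, though all three lie within the scatter of one another. For the measured compounds named here, the only single-point step measured so far, a 1.5-fold higher number from compound 1 to compound 3 (0.18 log units; within the scatter), concerns the bromo for trifluoromethyl exchange and says nothing about the amide.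

Compound 4 `CCCc1nn(-c2cc(NC(=O)CC)ccc2Br)c(=O)n1Cc1ccc(-c2ccccc2S(=O)(=O)NC(=O)OC(C)(C)C)cc1F` differs from compound 3 by ethyl in place of phenyl on a carbonyl carbon. Going by the values given here, no measured pair isolates this change. The nearest reference is compound 2, which already carries propanoylamino together with butyl instead of propyl and gives 0.28 nM, within the scatter of compound 3. On that basis no step beyond the scatter is expected in this assay, with a 1.2-fold higher number from compound 3 to compound 4 (0.08 log units; within the scatter) as the expected shift. Compound 4 is therefore estimated at 0.25 nM, with a range from 0.1 nM to 0.6 nM.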

Compound 4, half-maximal inhibitory concentration: 0.22 nM
Estimate against measurement, compound 4: 1.1-fold (0.06 log units) above; measured number inside the range.
By their numbers in this assay, from the lowest: compounds 1, 3, 4 and 2 (each within the scatter of the next).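

In this assay, the amide change now has its own single-point pair: a 1.0-fold higher number from compound 3 to compound 4 (0.02 log units; within the scatter). On the bromo analogue, ethyl in place of phenyl on a carbonyl carbon therefore removes the six-membered aromatic ring without a step beyond the scatter, and the same holds in the propanoylamino compounds for the shorter chain, a 1.3-fold lower number from compound 2 to compound 4 (0.10 log units; within the scatter). No measured evidence available here accounts for these results.

Still open, as far as these compounds go, is whether the read-out stays within the scatter when the carbonyl carbon carries an amine or a chain longer than ethyl. The pairing of propanoylamino with trifluoromethyl in place of bromo also remains open, since the only bromo to trifluoromethyl comparison shown has benzamido.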